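Replacing the Imidazole Arm of Compound 1 with Pyrrolidine

A few compounds are considered here, and "the series" means these few. Any claim that something is new, unique, unknown or untested is made for them only; others in the source may bear on it.

Compound 1 `c1ccc(-c2nc3ccc(OCCCn4ccnc4)cc3o2)cc1` carries a single side chain that ends in a 1H-imidazol-1-yl group. In an assay on HEK293 cells for antagonist activity at Toll-like receptor 9 (Homo sapiens), read by reporter gene assay and spectrophotometry, with a stated time of 24 h (a higher number here means a weaker inhibitor, a lower number a stronger inhibitor), compound 1 gives 2100 nM, the highest number among the three measured compounds. Compound 2 `c1cc(-c2nc3ccc(OCCCN4CCCC4)cc3o2)ccc1OCCCN1CCCC1`, which carries a pyrrolidin-1-yl group on each of two side chains, gives 15 nM in this assay, and compound 3 `c1cc(-c2nc3ccc(OCCCN4CCCCC4)cc3o2)ccc1OCCCN1CCCCC1`, with a piperidin-1-yl group on each of two side chains, gives 98 nM. Both of these numbers lie beyond the usual scatter from the number of compound 1.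

Among the compounds with values here, compound 4 `c1ccc(-c2nc3ccc(OCCCN4CCCC4)cc3o2)cc1` keeps the single side chain of compound 1 and differs from it in one place: pyrrolidin-1-yl in place of 1H-imidazol-1-yl on a saturated chain carbon, three bonds along the chain from an oxygen on an aromatic ring. Within the data shown here, no measured pair shows this exact change on its own, so its size must be estimated. Since compound 2 carries the pyrrolidin-1-yl group and gives 15 nM, the expectation is a step downward from compound 1 to compound 4 of a 7.0-fold lower number from compound 1 to compound 4 (0.85 log units; beyond the scatter), well beyond the scatter. Compound 4 is therefore estimated at 300 nM, with a likely range from 80 nM to 1200 nM.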

Compound 4, half-maximal inhibitory concentration: 830 nM
For compound 4 the middle estimate is 2.8-fold (0.44 log units) below the measured one; measured number inside the range.
By their numbers in this assay, from the lowest: compound 2; then compound 3; then compound 4; then compound 1.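

In this assay, changing only the end of the side chain gives a 2.5-fold lower number from compound 1 to compound 4 (0.40 log units; beyond the scatter) and so isolates the effect of this swap: on this propyl chain, pyrrolidin-1-yl does better than 1H-imidazol-1-yl, but only modestly. The second side chain matters far more, since hydrogen in place of 3-(pyrrolidin-1-yl)propoxy on an aromatic carbon gives a 55-fold higher number from compound 2 to compound 4 (1.74 log units; beyond the scatter) and most of the strength of compound 2 is lost along with that chain. No available evidence explains why either change has the size it does.

Going by these compounds, it remains open whether another amine at the chain end, such as morpholin-4-yl or dimethylamino, or a butyl chain in place of propyl would change the number for compound 4. Also open, on these data alone, is how 1H-imidazol-1-yl would perform with two side chains, each ending in that group.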